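A few compounds are considered here, and "the series" means these few. Any claim that something is new, unique, unknown or untested is made for them only; others in the source may bear on it.

The measured compounds:
compound 1 `O=C(CSc1nnc(-c2ccncc2)o1)N/N=C/c1ccccc1` gives 22100 nM in a functional assay on BGC-823 cells (Homo sapiens) for cytotoxicity, read by MTT assay, with a stated time of 48 h; on this read-out lower numbers stand for stronger inhibition and higher numbers for weaker inhibition
compound 2 `O=C(CSc1nnc(-c2ccncc2)o1)N/N=C/c1ccc(O)cc1` gives 7940 nM in this assay
compound 3 `O=C(CSc1nnc(-c2ccncc2)o1)N/N=C/c1cccc(C(F)(F)F)c1` gives 13000 nM in this assay

Among these three, compound 2 has the lowest number in this assay, though its gap to compound 3 lies within the scatter, so the two cannot be ordered. Among the compounds with values here, the one step beyond the scatter is a 2.8-fold lower number from compound 1 to compound 2 (0.44 log units; beyond the scatter); the other, a 1.7-fold lower number from compound 1 to compound 3 (0.23 log units; within the scatter), is within it. Both steps start from the unsubstituted compound 1 and each adds a single group to its phenyl ring.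

Compound 4 `O=C(CSc1nnc(-c2ccncc2)o1)N/N=C/c1ccccc1[N+](=O)[O-]` is built from compound 2 by a different kind of exchange: 2-nitrophenyl in place of 4-hydroxyphenyl on a carbon with a double bond to nitrogen. Within the data shown here, no measured pair swaps one substituted phenyl for another, and no measured compound carries a nitro group, so the two steps from compound 1 bear on this change only indirectly. They show that a substituent on this ring moves the number in this assay by a modest amount at most, and in compound 3 by less than the scatter. The writer therefore expects compound 4 to land near compound 2 and compound 3, with a step of a 1.6-fold higher number from compound 2 to compound 4 (0.21 log units; within the scatter) that is not beyond the scatter. Compound 4 is estimated at 13000 nM in this assay, within 5000 nM to 35000 nM.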

Compound 4, half-maximal inhibitory concentration: 41600 nM
Estimate against measurement, compound 4: 3.2-fold (0.51 log units) below; the measured number lies above the stated range.
By their numbers in this assay, from the lowest: compounds 2, 3, 1 and 4 (each within the scatter of the next, the first and the last beyond it).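

The exchange of 4-hydroxyphenyl for 2-nitrophenyl on a carbon with a double bond to nitrogen gives a 5.2-fold higher number from compound 2 to compound 4 (0.72 log units; beyond the scatter) in this assay, so two substituted phenyl groups at this position can differ by more than the scatter, which the steps from compound 1 alone did not show. Adding a nitro group to the phenyl ring gives a 1.9-fold higher number from compound 1 to compound 4 (0.27 log units; within the scatter), which lies within the scatter, so compound 4 cannot be ordered against the unsubstituted compound 1, and among the three substituents only the hydroxy of compound 2 stands beyond the scatter from compound 1. Nothing measured here accounts for the difference between these groups.

This step exchanges the group and its place on the ring together, so the compounds shown cannot say which of the two matters. Going by these compounds, whether an amine or a carboxylic acid on the phenyl ring would give a lower number, as hydroxy does in compound 2, also remains open.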